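Hydroxymethyl to aminomethyl on a GPR88 agonist

The source may hold more compounds than are shown below. What is called first, only, known or untested is meant among the compounds shown, and "the series" means these compounds.

Compound 1 `CC[C@H](C)[C@H](N)CN(C(=O)[C@@H]1C[C@H]1c1ccccc1)c1ccc(-c2ccccc2)cc1`: 230 nM; 800 nM (2 entries)
Compound 2 `CC[C@H](C)[C@H](N)CN(C(=O)[C@@H]1C[C@H]1c1ccccc1)c1ccc(-c2ccc(CO)cc2)cc1`: 1100 nM

In a functional assay for agonist activity at G protein-coupled receptor 88 (Homo sapiens), read by HTRF and cAMP accumulation (a lower number here means that less compound is needed, a higher number that more compound is needed for the effect), compound 1 gives 230 nM; 800 nM (2 entries) and compound 2 gives 1100 nM; compound 2 is the only single number shown for it, with one further entry that carries no number. Compound 3 `CC[C@H](C)[C@H](N)CN(C(=O)[C@@H]1C[C@H]1c1ccccc1)c1ccc(-c2ccc(CN)cc2)cc1` differs from compound 2 by amino in place of hydroxy on a saturated chain carbon bound to an aromatic carbon. Among the measured compounds shown here, no step between measured compounds is available to gauge this change, so compound 3 is expected to stay near compound 2, with a step of a 1.4-fold lower number from compound 2 to compound 3 (0.14 log units; within the scatter) that is estimated to lie within the usual scatter. Compound 3 is thus estimated at 800 nM, between 250 nM and 2500 nM.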

Compound 3, half-maximal effective concentration: > 30000 nM
Compound 3 gave a limit, no number; the forecaster's own chance of this, stated with the estimate: 10%; middle value at least 37-fold (1.57 log units) away from the limit.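

Amino in place of hydroxy on this saturated chain carbon bound to an aromatic carbon is far from a silent exchange: this assay shows an at least 27-fold higher number from compound 2 to compound 3 (1.43 log units; beyond the scatter). The two groups match in heavy-atom, donor and acceptor counts, so those counts alone do not predict the outcome here. Compound 3 gives a limit and not a number: the limit of > 30000 nM in this assay, at which 1 of the 3 values shown sits.

As far as these compounds go, the true size of the step therefore stays open. Also open, from the compounds shown here alone, is whether a methoxy group, a carboxylic acid or a longer chain ending in an amine would be accepted at this place.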